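Solubility notes: bromo for amino on the pyridyl arm

This account rests on a few compounds, and the source may have more. Where it says the series, first, only, none or still open, it means among the compounds named here.

Three compounds of this series have a measured solubility. In a physicochemical assay for solubility (on this read-out higher numbers stand for higher solubility and lower numbers for lower solubility), compound 1 `S=c1[nH]nc(-c2ccncc2)n1-c1ccc2ncccc2c1` gives 15000 nM. Compound 2 `Nc1cc(-c2n[nH]c(=S)n2-c2ccc3ccccc3c2)ccn1` gives 100000 nM in this assay, the highest of the three numbers. Compound 3 `N/N=c1\[nH]nc(-c2ccncc2)n1-c1ccc2ccccc2c1` gives 65000 nM in this assay, a value that lies within the scatter of compound 2, so no order between the two is claimed. The number of compound 1 lies beyond the scatter below that of compound 2.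

Compound 4 `S=c1[nH]nc(-c2ccnc(Br)c2)n1-c1ccc2ccccc2c1` has not yet been measured in this assay. It differs from compound 2 in one place: bromo in place of amino on an aromatic carbon. Going by the values given here, no measured pair in the set isolates this change, so the size of the step has to be guessed. With the hydrogen-bond donor and acceptor of the amino group gone, the expected direction is toward a lower number in this assay, and the step is expected to be clearly beyond the scatter; compound 1, which carries no group at this position, gives 15000 nM, which supports a number of that order. The estimate for compound 4 in this assay is 10000 nM, with a range from 3000 nM to 35000 nM. The expected step of a 10-fold lower number from compound 2 to compound 4 (1.00 log units; beyond the scatter) is therefore a drop in solubility.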

Compound 4, solubility: 35000 nM
The estimate for compound 4 lay 3.5-fold (0.54 log units) below the measured number; measured number inside the range.
By their numbers in this assay, from the lowest: compound 1; then compounds 4, 3 and 2 (each within the scatter of the next, the first and the last beyond it).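

Going by these compounds alone, the first pair that isolates a change at this position reads in this assay as a 2.9-fold lower number from compound 2 to compound 4 (0.46 log units; beyond the scatter) for the move from 2-aminopyridin-4-yl to 2-bromopyridin-4-yl. The size of the step at this place, on an aromatic carbon next to the ring nitrogen, can now be read from a measured pair instead of being inferred from compounds that differ in more than one place, and it is modest. Amino, with its hydrogen-bond donor and acceptor, gives way to bromo, with neither, and compound 4 still stands at 35000 nM on this read-out, though this remains a single pair on a single core.

No supporting measurement bears on what lies behind the step.

Open, on these data alone, is how other groups at this place would read against amino and bromo, for example a methoxy group, a dimethylamino group or a carboxylic acid. Also open, as far as these compounds go, is whether bromo in place of amino gives a step of similar size on the core of compound 1, where the other aromatic ring differs from that of compound 2.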